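From 2-Methylbenzyl to 4-Methoxybenzyl on a Shared Core

The source may hold more compounds than are shown below. What is called first, only, known or untested is meant among the compounds shown, and "the series" means these compounds.

Of the compounds shown here, three sharing one core have been tested in an ADME assay on Huh-5-2 cells (Homo sapiens) for cytotoxicity, read by WST assay, with a stated time of 3 days; a higher number here means that more compound is tolerated, a lower number that less compound is tolerated. Compound 1 `O=c1c(OCc2ccccc2Br)c(-c2ccccc2)oc2cc(O)cc(O)c12` gives 12000 nM. Compound 2 `Cc1ccccc1COc1c(-c2ccccc2)oc2cc(O)cc(O)c2c1=O` gives 55000 nM, and compound 3 `COc1ccccc1COc1c(-c2ccccc2)oc2cc(O)cc(O)c2c1=O` gives 53000 nM. For the measured compounds named here, compound 2 thus holds the highest of the three numbers, yet its gap to compound 3 lies within the scatter, as a 1.0-fold lower number from compound 2 to compound 3 (0.02 log units; within the scatter) shows; the only steps beyond the scatter are a 4.6-fold higher number from compound 1 to compound 2 (0.66 log units; beyond the scatter) and a 4.4-fold higher number from compound 1 to compound 3 (0.65 log units; beyond the scatter).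

Compound 4 `COc1ccc(COc2c(-c3ccccc3)oc3cc(O)cc(O)c3c2=O)cc1` has not yet been measured in this assay. Compared with compound 2 the change is 4-methoxyphenyl in place of 2-methylphenyl on a saturated chain carbon bound to an oxygen on an aromatic ring.

Of the measured steps, the closest in kind is the swap of methoxy for methyl, where a 1.0-fold lower number from compound 2 to compound 3 (0.02 log units; within the scatter) left the number essentially unchanged. Going by the values given here, that swap, however, kept the substituent in its place on the ring, whereas compound 4 carries its methoxy on 4-methoxyphenyl in place of the methyl on 2-methylphenyl; no measured pair probes such a move. The steps of a 4.6-fold higher number from compound 1 to compound 2 (0.66 log units; beyond the scatter) and a 4.4-fold higher number from compound 1 to compound 3 (0.65 log units; beyond the scatter) concern bromo and say nothing about it. The expected step is therefore small, about a 1.1-fold lower number from compound 2 to compound 4 (0.04 log units; within the scatter), with the real uncertainty resting on the untested placement. Compound 4 is estimated at 50000 nM, within 20000 nM to 120000 nM.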

Compound 4, half-maximal cytotoxic concentration: 57000 nM
For compound 4 the middle estimate is 1.1-fold (0.06 log units) below the measured one, and the stated range covers the measured number.
By their numbers in this assay, from the lowest: compound 1; then compounds 3, 2 and 4 (each within the scatter of the next).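

Setting 4-methoxyphenyl in place of 2-methoxyphenyl gives the first measured test of where the methoxy sits on this ring, and in this assay the two compounds cannot be told apart (a 1.1-fold higher number from compound 3 to compound 4 (0.03 log units; within the scatter)). The broader swap, which alters both the group and its place on the ring, reads the same way (a 1.0-fold higher number from compound 2 to compound 4 (0.02 log units; within the scatter)), so across compounds 2, 3 and 4 this position shows no difference beyond the scatter. Compound 1 alone stands apart (a 4.8-fold higher number from compound 1 to compound 4 (0.68 log units; beyond the scatter)), and with steps beyond the scatter to all three others, 2-bromophenyl gives the lowest number of the set.

Still open, as far as these compounds go, is whether that lower number belongs to bromo wherever it sits or only to 2-bromophenyl, and whether an amine or a carboxylic acid on this ring, or a longer chain in place of the saturated chain carbon, would keep the number where compounds 2, 3 and 4 stand. No supporting measurement is available to explain any of these numbers.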